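Compound 4: a Methyl Ether on the Shared Core

This account rests on a few compounds, and the source may have more. Where it says the series, first, only, none or still open, it means among the compounds named here.

Measured so far in this series:
compound 1 `CCc1nc2ccccc2n1CCCCOc1ccccc1`: 21 uM
compound 2 `CCc1nc2ccccc2n1CCCCOc1ccc(C#N)cc1`: 27 uM
compound 3 `CCc1nc2ccccc2n1CCCCOc1ccc(C)c(Cl)c1`: 14 uM

The three compounds share one core and differ only in the group on the oxygen on a saturated carbon. In an ADME assay on Vero cells (Chlorocebus sabaeus) for cytotoxicity, read by luminescence, with a stated time of 2 days (a lower number here means that less compound is tolerated, a higher number that more compound is tolerated), compound 1 gives 21 uM, compound 2 gives 27 uM and compound 3 gives 14 uM. Compound 3 holds the lowest of the three numbers, yet none of the steps between them reaches beyond the scatter: a 1.5-fold lower number from compound 1 to compound 3 (0.18 log units; within the scatter), a 1.9-fold lower number from compound 2 to compound 3 (0.29 log units; within the scatter) and a 1.3-fold higher number from compound 1 to compound 2 (0.11 log units; within the scatter). So far, changes at this position have left the read-out essentially unmoved.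

Compound 4 `CCc1nc2ccccc2n1CCCCOC` carries a far smaller group at the same place: methyl in place of 3-chloro-4-methylphenyl on an oxygen on a saturated carbon. Within the data shown here, no measured step resembles this one, since each earlier step swapped one six-membered aromatic ring for another, whereas here the ring leaves altogether. The three small steps give no reason to expect a large shift, but they also do not cover a change of this kind, so the estimate is held loosely around the measured values. Compound 4 is expected to give 30 uM, within the range 14 uM to 70 uM, a step of a 2.1-fold higher number from compound 3 to compound 4 (0.33 log units; beyond the scatter) that is expected to stay near the scatter.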

Compound 4, half-maximal toxic concentration: > 50 uM
Compound 4 ended at the assay's limit; the forecaster's own chance of this, stated with the estimate: 20%; middle value at least 1.6-fold (0.22 log units) away from the limit.
By their numbers in this assay, from the lowest: compounds 3, 1 and 2 (each within the scatter of the next). At a limit, above all of these: compound 4.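

In this assay compound 4 gives > 50 uM, which is a limit of the assay and not a number: the limit of > 50 uM in this assay, at which 1 of the 4 values shown sits.

Even read from that limit, the change to methyl on the oxygen is the first at this position to go beyond the scatter, with an at least 3.5-fold higher number from compound 3 to compound 4 (0.55 log units; beyond the scatter) and an at least 2.3-fold higher number from compound 1 to compound 4 (0.37 log units; beyond the scatter), whereas the three aromatic groups had stayed within the scatter of one another. Compound 2 is the exception to this pattern, since an at least 1.8-fold higher number from compound 2 to compound 4 (0.26 log units; that floor lies within the scatter) gives only a floor, so the compounds shown do not separate it from compound 4, although the true gap may be larger.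

How much more compound is tolerated with methyl cannot be told from a limit, and a single compound without the aromatic ring cannot show whether the loss of the ring or the smaller size of the group matters. A longer chain such as butyl, or a group such as an amine or a carboxylic acid at this place, would be needed to test whether the higher number holds beyond methyl.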